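The source may report more compounds than this note shows. Statements on the series, on what has been measured and on what is new or still open speak of the compounds shown alone.

In an ADME assay on A549 cells (Homo sapiens) for cytotoxicity, read by resazurin assay, with a stated time of 48 h (a higher number here means that more compound is tolerated, a lower number that less compound is tolerated), compound 3 (`O=C(Nc1ccc(NCC2CCCC2)cc1Cl)c1cc(Cl)ccc1O`) gives 21500 nM. This lies within the usual scatter of both its measured relatives: compound 1 (`CCNc1ccc(NC(=O)c2cc(Cl)ccc2O)c(Cl)c1`) gives 30200 nM, and compound 2 (`CC(C)Nc1ccc(NC(=O)c2cc(Cl)ccc2O)c(Cl)c1`) gives 11000 nM. Compound 4 (`CN(C)c1ccc(NC(=O)c2cc(Cl)ccc2O)c(Cl)c1`) has dimethylamino in place of (cyclopentylmethyl)amino on an aromatic carbon. Among the compounds with values here, no measured compound carries dimethylamino, so the best guide is how far changes to the group on that nitrogen have moved the number. The steps of a 1.4-fold lower number from compound 1 to compound 3 (0.15 log units; within the scatter) and a 2.0-fold higher number from compound 2 to compound 3 (0.29 log units; within the scatter) stayed within the scatter, and only a 2.7-fold lower number from compound 1 to compound 2 (0.44 log units; beyond the scatter) went beyond it, modestly. No clear direction follows, so the expected change in this assay is small: a 1.1-fold higher number from compound 3 to compound 4 (0.05 log units; within the scatter). For compound 4, the estimated value is 24000 nM, with an expected range of 10000 nM to 55000 nM.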

Compound 4, half-maximal cytotoxic concentration: 85100 nM
Compound 4: the middle estimate sits 3.5-fold (0.55 log units) below what was measured; measured number outside the range, above it.
By their numbers in this assay, from the lowest: compounds 2, 3 and 1 (each within the scatter of the next, the first and the last beyond it); then compound 4.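

In this assay, this position proves able to move the number beyond the scatter, since dimethylamino raises it in every comparison: a 4.0-fold higher number from compound 3 to compound 4 (0.60 log units; beyond the scatter), a 7.7-fold higher number from compound 2 to compound 4 (0.89 log units; beyond the scatter) and a 2.8-fold higher number from compound 1 to compound 4 (0.45 log units; beyond the scatter). Within the data shown here, compound 4 is also the only compound here with no hydrogen-bond donor in this group, but a single compound cannot show that this feature is what matters. Nothing shown explains the rise. Going by these compounds, it remains open whether diethylamino or a pyrrolidine ring, which also carry no hydrogen on that nitrogen, would give a similarly high number.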